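The source may report more compounds than this note shows. Statements on the series, on what has been measured and on what is new or still open speak of the compounds shown alone.

Working notes on the series. Compound 1 `Oc1nnc(-c2ccccc2)c2cncn12` carries a hydroxy group on the shared core. Among the measured compounds shown here, in a functional assay for inhibition, with Homo sapiens as the target (on this read-out higher numbers stand for weaker inhibition and lower numbers for stronger inhibition), compound 1 gives 19000 nM, which is the only numerical value measured in this set so far, so compound 1 cannot be ranked against anything. Compound 2 `CSc1nnc(C)c2c(C)nc(C)n12` also carries a methylsulfanyl group, with methyl groups in place of the phenyl and on the core. In this assay compound 2 reaches only the assay limit of > 48000 nM, a limit rather than a number (the limit of > 48000 nM in this assay, at which 1 of the 2 values shown sits). For the measured compounds named here, compounds 1 and 2 differ in more than one place, so no single step between them can be drawn; together they show one number and one limit.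

Compound 3 `CSc1nnc(-c2ccccc2)c2cncn12` is not yet measured. It differs from compound 1 by methylsulfanyl in place of hydroxy on an aromatic carbon. Going by the values given here, no measured step of this kind exists in the set. The expected step of a 1.7-fold higher number from compound 1 to compound 3 (0.23 log units; within the scatter) points toward somewhat weaker inhibition, beyond the usual scatter but not large. For compound 3 the estimate in this assay is 32000 nM, with a range from 8000 nM to 130000 nM; a limit-only result is a real possibility.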

Compound 3, half-maximal inhibitory concentration: > 48000 nM
Compound 3 was reported as a limit; the forecaster's own chance of this, stated with the estimate: 40%; middle value at least 1.5-fold (0.17 log units) away from the limit.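

In this assay, methylsulfanyl in place of hydroxy on an aromatic carbon, between two ring nitrogen atoms, gives an at least 2.5-fold higher number from compound 1 to compound 3 (0.40 log units; beyond the scatter). Among the compounds shown here, this is the first single-place step, and with the phenyl and the rest of the shared core held constant, it shows that the group at this position affects the read-out, with the change from hydroxy to methylsulfanyl going toward weaker inhibition. The step is a bound and not a measured gap, as compound 3 gives a limit and not a number: the limit of > 48000 nM in this assay, at which 2 of the 3 values shown sit.

On these data alone, whether the weaker inhibition goes with the loss of hydroxy or with the arrival of methylsulfanyl stays open, and a methoxy group, an amine or a carboxylic acid at this position would bear on that question. The compounds shown also leave open how much of the change depends on the phenyl, as compound 2 differs from compound 3 in more than one place and no step between them can be read.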